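Carbamate to sulfonamide on the aminomethyl side chain

The compounds below may be only part of what the source reports. "The series", "measured", "known", "first", "only" and "open" are said of these compounds alone.

Working notes on the series. Compound 1 `COC(=O)NCC1Cc2ccc(NC(=O)c3cccc(C)c3-c3ccc(C(F)(F)F)cc3)cc2C1` is the reference point; in an assay on isolated protein for inhibition of microsomal triglyceride transfer protein large subunit (Homo sapiens) (on this read-out higher numbers stand for weaker inhibition and lower numbers for stronger inhibition), compound 1 gives 24 nM, the lowest of the three numbers in hand. Compound 2 `COC(=O)NCC1Cc2ccc(NC(=O)c3cc(C)cc(C)c3-c3ccc(C(F)(F)F)cc3)cc2C1` gives 40 nM, and the step of a 1.7-fold higher number from compound 1 to compound 2 (0.22 log units; within the scatter) stays within the scatter, so the two numbers are not distinguished. Compound 3 `COC(=O)NCC1Cc2ccc(NC(=O)c3cccc(C)c3-c3ccc(Cl)cc3)cc2C1` gives 100 nM, and the step of a 4.2-fold higher number from compound 1 to compound 3 (0.62 log units; beyond the scatter) is a modest loss that lies beyond the scatter.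

Compound 4 `Cc1cccc(C(=O)Nc2ccc3c(c2)CC(CNS(C)(=O)=O)C3)c1-c1ccc(C(F)(F)F)cc1` has not yet been measured. Its change from compound 1 is methylsulfonyl in place of methoxycarbonyl on an amine nitrogen; the amide, the biaryl part and the shared core are untouched. Among the compounds with values here, neither measured step bears on this side chain: both alter the aryl rings and leave the carbamate as it is, so there is no direct precedent in these data for the swap to methanesulfonamido. Within the data shown here, what can be said is that the only change to the side chain is a group-for-group replacement that keeps the hydrogen-bond donor and acceptor count, as counted above. Compound 4 is therefore expected to give 50 nM in this assay, with a range of 15 nM to 160 nM. This estimate means an expected step of a 2.1-fold higher number from compound 1 to compound 4 (0.32 log units; beyond the scatter), a loss near the edge of the scatter, with the direction uncertain.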

Compound 4, half-maximal inhibitory concentration: 150 nM
Compound 4: middle estimate off by 3.0-fold (0.48 log units), on the low side; the measured number falls inside the stated range.
By their numbers in this assay, from the lowest: compounds 1 and 2 (each within the scatter of the next); then compounds 3 and 4 (each within the scatter of the next).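

Within the data shown here, on the aminomethyl side chain, the change from the carbamate to the sulfonamide gives the first reading at this position: in this assay methylsulfonyl in place of methoxycarbonyl on the amine nitrogen gives a 6.3-fold higher number from compound 1 to compound 4 (0.80 log units; beyond the scatter), a modest loss that lies beyond the scatter. The two groups match in heavy atom count and in hydrogen-bond donors and acceptors, so this side chain is not indifferent to a replacement that leaves those counts unchanged, and such counts alone do not predict the number here. Nothing measured on either group accounts for this step, which therefore stands as an observation only.

The compounds shown leave open whether the loss belongs to the sulfonyl group as such or to this particular replacement, a question that an acetyl group, a urea or an ethylsulfonyl group on the same amine nitrogen would help to settle. They also leave open whether the step keeps its size when methylsulfonyl is paired with the chloro or dimethyl-substituted aryl parts of the series.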